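Cytotoxicity notes on the hydrazone series, toward compound 4

A few compounds are considered here, and "the series" means these few. Any claim that something is new, unique, unknown or untested is made for them only; others in the source may bear on it.

Compound 3 `O=C(NN=C1CC(c2ccccc2)NC(c2ccccc2)C1)c1ccc(F)cc1` is one of three compounds examined in a toxicity assay on BJ cells (Homo sapiens) for cytotoxicity, read by MTT assay, with a stated time of 24 h; a higher number here means a weaker inhibitor, a lower number a stronger inhibitor. In this assay compound 3 gives > 400000 nM, which is a limit of the assay and not a number. Compound 2 `O=C(NN=C1CC(c2ccccc2)NC(c2ccccc2)C1)c1ccc(Cl)cc1` gives > 400000 nM in this assay, likewise a limit. Compound 1 `CCOC(=O)N1CCC(=NNC(=O)c2ccc([N+](=O)[O-])cc2[N+](=O)[O-])CC1` gives > 400000 nM in this assay, again a limit. Going by the values given here, the one step between measured compounds that differ in one place, fluoro in place of chloro on an aromatic carbon, is a step that the two limits leave unreadable from compound 2 to compound 3. The whole picture is summed up by the limit of > 400000 nM in this assay, at which 3 of the 3 values shown sit. Compound 3 thus sits at the limit together with the other two, and no order among the three can be read from the values.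

Compound 4 `Cc1ccc(C(=O)NN=C2CC(c3ccccc3)NC(c3ccccc3)C2)cc1` differs from compound 3 by methyl in place of fluoro on an aromatic carbon. Among the compounds with values here, no measured step bears directly on a methyl entering for a fluoro; the only measured step, chloro to fluoro on an aromatic carbon, is unreadable between two limits. With three of three values at the limit, the expectation for compound 4 is that this assay again reports the limit, so the step of a number no higher from compound 3 to compound 4 (the limit leaves the size open) is expected to show nothing readable. Compound 4 is estimated at 400000 nM, with a range from 100000 nM to 1000000 nM.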

Compound 4, half-maximal inhibitory concentration: > 400000 nM
Compound 4 was reported as a limit; the forecaster's own chance of this, stated with the estimate: 85%; the middle value sits exactly at the limit.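

In this assay compound 4 gives > 400000 nM, a limit of the assay and not a number. No new step can be read between compound 4 and compound 2 or compound 3, and the picture is unchanged: the limit of > 400000 nM in this assay, at which 4 of the 4 values shown sit.

The compounds shown leave open whether any member of this series gives a readable value in this assay, and how chloro, fluoro and methyl would order there.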